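This account rests on a few compounds, and the source may have more. Where it says the series, first, only, none or still open, it means among the compounds named here.

Measured in a functional assay on the whole organism for inhibition, with Mus musculus as the target; on this read-out higher numbers stand for an effect only at larger amounts of compound and lower numbers for an effect already at smaller amounts:
- compound 1 `CN1Cc2c(N)cccc2C(c2ccc(Cl)cc2)C1`: 1.6 mg/kg
- compound 2 `CCNC(=O)Nc1cccc2c1CN(C)CC2c1ccccc1`: 80 mg/kg

Compound 2, at 80 mg/kg, has the higher of the two numbers, and the gap to compound 1 lies beyond the usual scatter. Compound 3 `CN1Cc2c(NC(=O)OCc3ccccc3)cccc2C(c2ccccc2)C1` has benzyloxy in place of ethylamino on a carbonyl carbon. Going by the values given here, the two measured compounds differ in more than one place, so no measured step isolates this change, and any forecast is uncertain. A modest step toward a lower number is expected, shown as a 2.7-fold lower number from compound 2 to compound 3 (0.43 log units; beyond the scatter). The estimated value for compound 3 is 30 mg/kg, with an expected range from 6 mg/kg to 120 mg/kg.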

Compound 3, dose for half-maximal effect: about 15 mg/kg
Beside the measured number, compound 3's estimate is 2.0-fold (0.30 log units) above it, within the range that was stated.
By their numbers in this assay, from the lowest: compound 1; then compound 3; then compound 2.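

In this assay the carbonyl carbon of this side group proves to be a place where a change counts: benzyloxy in place of ethylamino gives a 5.3-fold lower number from compound 2 to compound 3 (0.73 log units; beyond the scatter). The larger group, with its six-membered aromatic ring and without the hydrogen-bond donor of ethylamino, is therefore accepted here in this whole-animal test. Nothing measured here explains the step.

The ring and the oxygen enter together, and the compounds shown do not separate their contributions. Methoxy or phenylamino on the same carbonyl carbon would help to tell them apart.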